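Methyl removal on the pyrrolidin-1-yl core: compound 4

This account rests on a few compounds, and the source may have more. Where it says the series, first, only, none or still open, it means among the compounds named here.

Three compounds have numbers and one does not. Compound 1 `N/C(=N\NC(=S)N1CCOCC1)c1ccccn1`, compound 2 `Cc1cccc(/C(N)=N/NC(=S)N2CCOCC2)n1` and compound 3 `Cc1cccc(/C(N)=N/NC(=S)N2CCCC2)n1` are measured; compound 4 `N/C(=N\NC(=S)N1CCCC1)c1ccccn1` is not. In a functional assay on A-375 cells (Homo sapiens) for cytotoxicity, read by MTT assay, with a stated time of 72 h (a higher number here means a weaker inhibitor, a lower number a stronger inhibitor), compound 1 gives 680 nM, compound 2 gives 14000 nM and compound 3 gives 2900 nM.

Two single changes connect the measured set. The first is hydrogen in place of methyl on an aromatic carbon and it gave a 21-fold lower number from compound 2 to compound 1 (1.31 log units; beyond the scatter). The second is how the core of compound 3 differs from the core of compound 2: pyrrolidin-1-yl in place of morpholin-4-yl on a thiocarbonyl carbon It gave a 4.8-fold lower number from compound 2 to compound 3 (0.68 log units; beyond the scatter).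

Compound 4 differs from compound 3 as follows: hydrogen in place of methyl on an aromatic carbon The place is described in the same words as for the change from compound 2 to compound 1, so this is the same change, made once more on a different core. Within the data shown here, with only one precedent in this assay, the expectation is that the step will be of similar size because a 21-fold lower number from compound 2 to compound 1 (1.31 log units; beyond the scatter) was large and beyond the scatter; the expected step is a 16-fold lower number from compound 3 to compound 4 (1.21 log units; beyond the scatter). Compound 4 is therefore estimated at 180 nM in this assay, with an expected range from 60 nM to 550 nM.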

Compound 4, half-maximal inhibitory concentration: 600 nM
The estimate for compound 4 lay 3.3-fold (0.52 log units) below the measured number; the measured number lies above the stated range.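

In this assay, hydrogen in place of methyl on an aromatic carbon again gives a lower number on the pyrrolidin-1-yl core, a 4.8-fold lower number from compound 3 to compound 4 (0.68 log units; beyond the scatter), so the direction of the change carries over but its size does not: the same change on two cores in this assay, a 21-fold lower number (1.31 log units; beyond the scatter) from compound 2 to compound 1 and a 4.8-fold lower number (0.68 log units; beyond the scatter) from compound 3 to compound 4, 4.3-fold (0.63 log units) apart, beyond the scatter of two such steps.

On the cores without the methyl, pyrrolidin-1-yl in place of morpholin-4-yl gives a 1.1-fold lower number from compound 1 to compound 4 (0.05 log units; within the scatter), so this second change does not carry over at a fixed size either: the same change on two cores in this assay, a 4.8-fold lower number (0.68 log units; beyond the scatter) from compound 2 to compound 3 and a 1.1-fold lower number (0.05 log units; within the scatter) from compound 1 to compound 4, 4.3-fold (0.63 log units) apart, beyond the scatter of two such steps.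

Among these compounds, each change is seen on only two cores, which shows that step size depends on the core here but does not show why, and gives no reliable size for a further core.

Still open, on these data alone, is how other groups on the same aromatic carbon, such as ethyl, methoxy or chlorine, would compare with methyl and hydrogen. Also open, as far as these compounds go, is whether piperidin-1-yl or an open-chain dimethylamino group on the thiocarbonyl carbon would follow compound 1 and compound 4 or depart from them.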